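A few compounds are considered here, and "the series" means these few. Any claim that something is new, unique, unknown or untested is made for them only; others in the source may bear on it.

Measured compounds:
- compound 1, `Cc1cc(O)cc(-c2nn(CC#N)cc2-c2ccnc(-c3ccc(Oc4ccccc4)cc3)c2)c1`: -99%
- compound 2, `COc1cc(C)cc(-c2nn(CC#N)cc2-c2ccnc(-c3ccc(N(C)C)cc3)c2)c1`: -40%

In a functional assay on SK-OV-3 cells (Homo sapiens) for cytotoxicity, read by sulforhodamine B assay, with a stated time of 48 h, tested at 10 uM (a higher number here means a weaker effect of the compound at the concentration tested, a lower number a stronger effect), compound 1 gives -99%, and compound 2 gives -40%. Of the two numbers, compound 2 stands at the higher one, the weaker effect; compound 1 lies well below it, and that gap is beyond the usual scatter of repeated measurements. The two compounds differ in more than one place at once, so no single change can be tied to this gap.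

Compound 3, `Cc1cc(O)cc(-c2nn(CC#N)cc2-c2ccnc(-c3ccc(N(C)C)cc3)c2)c1`, has not yet been measured in this assay. It is built from compound 2 by one change: hydrogen in place of methyl on an oxygen on an aromatic ring. Cut one bond further out, the same change reads methoxy to hydroxy, or 3-methoxy-5-methylphenyl to 3-hydroxy-5-methylphenyl. Within the data shown here, compound 1 also carries the hydroxy group, but it differs from compound 3 elsewhere as well, so no measured pair isolates this exact change.

For compound 3 a moderate step downwards in this assay is expected, that is a somewhat stronger effect, of about a number 20 percentage points lower from compound 2 to compound 3 (beyond the scatter), with wide uncertainty. Compound 3 is estimated at -60%, in a range from -100% to -20%.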

Compound 3, a percentage reported as activity, at one concentration (the size of the read-out at that concentration, not a potency): -38%
Compound 3: the middle estimate sits 22 percentage points below what was measured, and the stated range covers the measured number.
By their numbers in this assay, from the lowest: compound 1; then compounds 2 and 3 (each within the scatter of the next).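

In this assay the change from methoxy to hydroxy on the aromatic ring gives a number 2 percentage points higher from compound 2 to compound 3 (within the scatter), so with dimethylamino kept in place, the two groups cannot be told apart at this position. Among these compounds, compound 3 also forms the first pair that differs from compound 1 in one place only: dimethylamino in place of phenoxy gives a number 61 percentage points higher from compound 1 to compound 3 (beyond the scatter), a large step that shows the phenoxy-bearing compound 1 has much the stronger effect of this pair. Nothing measured here gives a reason for either step.

The level result for methoxy and hydroxy is shown only for compounds carrying dimethylamino, so it remains open whether the two groups would also match alongside phenoxy. From the compounds shown here alone, it is also open how a longer ether such as ethoxy, or an amine in place of the hydroxy, would read at this position, and how smaller groups than phenoxy, such as methoxy or fluorine, would fall within the large step seen at the other place.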